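The compounds below may be only part of what the source reports. "The series", "measured", "known", "first", "only" and "open" are said of these compounds alone.

Within the data shown here, all the compounds here share one core, and compound 1 (`COc1ccc(/C=C\C(=O)O)c(OCc2cn(-c3ccccc3)nn2)c1CC=C(C)C`) supplies the only number so far: in a functional assay on NCI-H322 cells (Homo sapiens) for cytotoxicity, read by MTT assay, with a stated time of 24 h (on this read-out higher numbers stand for weaker inhibition and lower numbers for stronger inhibition), compound 1 gives 29200 nM. On these data alone, compound 2 (`COc1ccc(-n2cc(COc3c(/C=C\C(=O)O)ccc(OC)c3CC=C(C)C)nn2)cc1`) offers no such reference point, since in this assay compound 2 is recorded as "not determined" (no result reported), so its standing is unknown. Compound 3 (`COc1ccc(/C=C\C(=O)O)c(OCc2cn(-c3cccnc3Cl)nn2)c1CC=C(C)C`) differs from compound 2 in one place, on an aromatic nitrogen of a five-membered aromatic ring with 3 nitrogen, where 2-chloropyridin-3-yl stands in place of 4-methoxyphenyl: 2-chloropyridin-3-yl in place of 4-methoxyphenyl on an aromatic nitrogen. Among the measured compounds shown here, no measured pair shows what a change of this kind does, so no step beyond the usual scatter is expected in either direction. The expectation therefore rests on compound 1 at 29200 nM, with a wide margin. Compound 3 is expected at about 27000 nM, with an estimated range of 10000 nM to 75000 nM.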

Compound 3, half-maximal inhibitory concentration: 42200 nM
For compound 3 the middle estimate is 1.6-fold (0.19 log units) below the measured one; the range from low to high includes it.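

In this assay, 2-chloropyridin-3-yl in place of phenyl on the aromatic nitrogen gives a 1.4-fold higher number from compound 1 to compound 3 (0.16 log units; within the scatter), a step that stays within the usual scatter. Among these compounds, until now no measured pair existed for this position, and this one shows that a change of ring, from carbon only to one with a hetero atom and with chlorine added, need not move the number beyond that scatter. The two numbers therefore sit at the same level, and this single pair says nothing about other groups at this place.

On these data alone, compound 2 has no result, so the step from it to compound 3 cannot be read, and the effect of 4-methoxyphenyl remains unknown, as does that of an amine or a longer carbon chain on this nitrogen. Nothing available explains why these two rings give numbers at one level.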